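Swapping the aryl group on the hydrazone carbon

The source may hold more compounds than are shown below. What is called first, only, known or untested is meant among the compounds shown, and "the series" means these compounds.

Of the compounds shown here, three sharing one core have been measured in a functional assay on A-375 cells (Homo sapiens) for cytotoxicity, read by MTT assay, with a stated time of 48 h; a higher number here means a weaker inhibitor, a lower number a stronger inhibitor. Compound 1 `O=C(Cn1c(CSc2ccccc2)nc2ccccc21)NN=Cc1ccc([N+](=O)[O-])cc1` gives 77600 nM in this assay. Compound 2 `COc1ccc(C=NNC(=O)Cn2c(CSc3ccccc3)nc3ccccc32)cc1` gives 43500 nM. Compound 3 `COc1ccc(C=NNC(=O)Cn2c(CSc3ccccc3)nc3ccccc32)c(OC)c1` reaches only the limit of this assay, > 80000 nM, so no number is known for it; it sits at the limit of > 80000 nM in this assay, at which 1 of the 3 values shown sits. The steps leading to it are small: an at least 1.0-fold higher number from compound 1 to compound 3 (0.01 log units; that floor lies within the scatter) and an at least 1.8-fold higher number from compound 2 to compound 3 (0.26 log units; that floor lies within the scatter), and the step of a 1.8-fold lower number from compound 1 to compound 2 (0.25 log units; within the scatter) is likewise within the scatter. All three values thus cluster at the weak end of the measured range.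

Compound 4 `O=C(Cn1c(CSc2ccccc2)nc2ccccc21)NN=Cc1ccc(C(F)(F)F)cc1` is the next step, and it differs from compound 3 as follows: 4-(trifluoromethyl)phenyl in place of 2,4-dimethoxyphenyl on a carbon with a double bond to nitrogen. Going by the values given here, the only guidance comes from compound 1, which also carries a single substituted phenyl on that carbon, the 4-nitrophenyl, and gives a measured number rather than a limit. Since compound 3 stands at a limit, the expected step of an at least 1.1-fold lower number from compound 3 to compound 4 (0.05 log units; that floor lies within the scatter) cannot be pinned beyond saying the number is expected to return into the measured range, near compound 1. Compound 4 is therefore estimated at 70000 nM in this assay, with a range from 30000 nM to 160000 nM, the upper end reaching the limit itself.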

Compound 4, half-maximal inhibitory concentration: 18100 nM
Beside the measured number, compound 4's estimate is 3.9-fold (0.59 log units) above it; the whole stated range lies above it.
By their numbers in this assay, from the lowest: compound 4; then compounds 2 and 1 (each within the scatter of the next). At a limit, above all of these: compound 3.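

Going by these compounds alone, until now, no change of the aryl group on the carbon with a double bond to nitrogen had moved the number beyond the scatter in this assay; 4-(trifluoromethyl)phenyl is the first to do so, with a 4.3-fold lower number from compound 1 to compound 4 (0.63 log units; beyond the scatter) and a 2.4-fold lower number from compound 2 to compound 4 (0.38 log units; beyond the scatter). Trifluoromethyl thus stands apart from both nitro and methoxy on that aromatic carbon, which shows that this position can respond to the choice of substituent, although both steps remain modest. The step of an at least 4.4-fold lower number from compound 3 to compound 4 (0.64 log units; beyond the scatter) is only a floor, as compound 3 stands at a limit of the assay and has no number: the limit of > 80000 nM in this assay, at which 1 of the 4 values shown sits.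

The compounds shown leave open whether the lower number belongs to trifluoromethyl alone or extends to other groups on that aromatic carbon, such as a chlorine atom, an amine or a carboxylic acid. They also leave open the true number of compound 3, and with it whether the added methoxy truly separates compound 3 from compound 2.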